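This account rests on a few compounds, and the source may have more. Where it says the series, first, only, none or still open, it means among the compounds named here.

Compound 1 `COc1ccc(C(=O)c2ccc(OC)c3c2C=CC(C)(C)O3)c(NC(=O)CN)c1` and compound 2 `CNCC(=O)Nc1cc(OC)ccc1C(=O)c1ccc(OC)c2c1C=CC(C)(C)O2` share one core; compound 3 `C=C(c1ccc(OC)cc1NC(=O)CN)c1ccc(OC)c2c1C=CC(C)(C)O2` and compound 4 `C=C(c1ccc(OC)cc1NC(=O)CNC)c1ccc(OC)c2c1C=CC(C)(C)O2` share another. The difference between the two cores is not broken down here. In a functional assay on A549 cells (Homo sapiens) for antiproliferative activity, read by MTT assay, with a stated time of 48 h (on this read-out lower numbers stand for stronger inhibition and higher numbers for weaker inhibition), compound 1 gives 420 nM, and compound 2 gives 1370 nM. The change between them, (methyl in place of hydrogen on an amine nitrogen), produced a 3.3-fold higher number from compound 1 to compound 2 (0.51 log units; beyond the scatter). Compound 3 gives 90 nM in this assay, the lowest of the three values. Compound 4 carries the same change as compound 2 relative to its partner, (methyl in place of hydrogen on an amine nitrogen), at a place described in the same words, so the same kind of shift is expected. On the strength of the step from compound 1 to compound 2, a 3.3-fold higher number from compound 1 to compound 2 (0.51 log units; beyond the scatter), the step to compound 4 is expected to be a 3.3-fold higher number from compound 3 to compound 4 (0.52 log units; beyond the scatter). Compound 4 is therefore estimated to give 300 nM in this assay, likely between 120 nM and 750 nM.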

Compound 4, half-maximal inhibitory concentration: 320 nM
The estimate for compound 4 lay 1.1-fold (0.03 log units) below the measured number; the range from low to high includes it.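

In this assay, methyl in place of hydrogen on the amine nitrogen gave a 3.6-fold higher number from compound 3 to compound 4 (0.55 log units; beyond the scatter), so inhibition weakened on this core much as it did on the core of compound 1. The two steps agree: the same change on two cores in this assay, a 3.3-fold higher number (0.51 log units; beyond the scatter) from compound 1 to compound 2 and a 3.6-fold higher number (0.55 log units; beyond the scatter) from compound 3 to compound 4, 1.1-fold (0.04 log units) apart, within the scatter of two such steps. For these two cores, the effect of the change carried over from one to the other, but two pairs set no rule for other cores and do not explain why the number rises.

The compounds shown leave open how an ethyl group on that amine nitrogen, or a dimethylamino group in place of the methylamino group, would behave. Going by these compounds, whether a longer chain would follow the same pattern on both cores also remains open.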